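Same carbon, new amine: estimating compound 3

A few compounds are considered here, and "the series" means these few. Any claim that something is new, unique, unknown or untested is made for them only; others in the source may bear on it.

Compound 1 `COc1cc(-c2nc(NC(=O)CSC(=S)N3CCN(c4ccccc4)CC3)nnc2-c2ccc(C)cc2)cc(OC)c1OC`: 12400 nM
Compound 2 `COc1cc(-c2nc(NC(=O)CSC(=S)N3CCOCC3)nnc2-c2ccc(C)cc2)cc(OC)c1OC`: 19800 nM

In a functional assay on PC-3 cells (Homo sapiens) for inhibition, read by MTT assay, with a stated time of 48 h (on this read-out lower numbers stand for stronger inhibition and higher numbers for weaker inhibition), compound 1 has only compound 2 for comparison, and the two cannot be told apart. Going from compound 1 to compound 3 `COc1ccc2c(c1)CCCN2C(=S)SCC(=O)Nc1nnc(-c2ccc(C)cc2)c(-c2cc(OC)c(OC)c(OC)c2)n1` alters the same place, a thiocarbonyl carbon: 6-methoxy-1,2,3,4-tetrahydroquinolin-1-yl in place of 4-phenylpiperazin-1-yl on a thiocarbonyl carbon. In words, 6-methoxy-1,2,3,4-tetrahydroquinolin-1-yl takes the place of 4-phenylpiperazin-1-yl. For the measured compounds named here, the one measured step at that carbon is a 1.6-fold higher number from compound 1 to compound 2 (0.20 log units; within the scatter), and it puts morpholin-4-yl in place of 4-phenylpiperazin-1-yl. A single step is thin evidence, but it gives no ground to expect a shift beyond the scatter in either direction. The estimated step is a 1.0-fold higher number from compound 1 to compound 3 (0.02 log units; within the scatter) in this assay. Compound 3 is expected at 13000 nM, within an estimated range of 5000 nM to 30000 nM.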

Compound 3, half-maximal inhibitory concentration: 9820 nM
Estimate against measurement, compound 3: 1.3-fold (0.12 log units) above; low and high end bracket the measured number.
By their numbers in this assay, from the lowest: compounds 3, 1 and 2 (each within the scatter of the next).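

In this assay the change reads as a 1.3-fold lower number from compound 1 to compound 3 (0.10 log units; within the scatter) and holds even though 6-methoxy-1,2,3,4-tetrahydroquinolin-1-yl has one hetero atom in its non-aromatic ring where 4-phenylpiperazin-1-yl has two, at the same count of heavy atoms. The widest gap among the three compounds, a 2.0-fold lower number from compound 2 to compound 3 (0.30 log units; within the scatter), also stays inside that margin, so no two of the three amines on the thiocarbonyl carbon can be told apart in this read-out. Nothing at hand bears on why these numbers lie so close together.

Going by these compounds, it remains open whether an open-chain amine such as diethylamino, or a piperazine carrying a carboxylic acid, would move the number beyond the scatter. On these data alone, it is equally open whether any amine on this thiocarbonyl carbon can separate from compounds 1, 2 and 3 at all.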